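Removing the Chloro Group from Compound 2

The source may report more compounds than this note shows. Statements on the series, on what has been measured and on what is new or still open speak of the compounds shown alone.

Three amides built on a shared core have been tested in a functional assay on the whole organism for inhibition, with Rattus norvegicus as the target, at a dose of 10 mg/kg by the oral route; a lower number here means a weaker effect, a higher number a stronger effect of the compound at the dose given. Compound 1 `O=C(Nc1nn[nH]n1)c1cccnc1` gives 3% in this assay. Compound 2 `O=C(Nc1nn[nH]n1)c1ncccc1Cl` gives 22%. Compound 3 `Cc1cc(Cl)cc(C(=O)Nc2nn[nH]n2)n1` gives 100%. Compound 2 therefore stands second highest of the three: its nearest neighbour, compound 1, lies lower by a margin beyond the scatter, and compound 3 lies far higher, also beyond the scatter.

Compound 4 `O=C(Nc1nn[nH]n1)c1ccccn1` has not yet been measured. Its structure differs from compound 2 in one place: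
hydrogen in place of chloro on an aromatic carbon

Going by the values given here, no pair of measured compounds isolates this change, so no measured step can be borrowed. Among the compounds with values here, the only measured compound without a chloro group, compound 1, gives 3% and sits at the bottom of the set. On that basis the expected step of a number 14 percentage points lower from compound 2 to compound 4 (beyond the scatter) is downward and probably just beyond the scatter. Compound 4 is estimated to give 8% in this assay, within a range from 0% to 25%.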

Compound 4, a percentage reported as inhibition, in the whole organism at one dose (the size of the read-out at that dose, not a potency): 35%
Estimate against measurement, compound 4: 27 percentage points below; measured number above the stated range.
By their numbers in this assay, from the lowest: compound 1; then compound 2; then compound 4; then compound 3.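

In this assay, hydrogen in place of chloro on this aromatic carbon gives a number 13 percentage points higher from compound 2 to compound 4 (beyond the scatter), so the step runs upward and the chloro group is not required for the effect at this dose. The earlier compounds shown here could not show this, since none of the measured pairs isolated a change at this position, ortho to a group of 8 heavy atoms. No measurement here bears on why the number rises when the chloro group leaves, and the step stands without an explanation.

The compounds shown do not tell how a methyl group, a methoxy group or an amine on this same aromatic carbon would compare with hydrogen and chloro. They also leave open whether this change would run the same way on a core carrying further groups, such as that of compound 3.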